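The source may hold more compounds than are shown below. What is called first, only, known or untested is meant among the compounds shown, and "the series" means these compounds.

Working notes on the camphor-derived sulfonylpiperazine series. Within the data shown here, compound 1 `CC1(C)[C@@H]2CC[C@@]1(CS(=O)(=O)N1CCN(c3ccc(Br)cn3)CC1)C(=O)C2` carries a 5-bromopyridin-2-yl group on the piperazine and is the weaker of the two compounds measured so far: in a functional assay on CHO-K1 cells for antagonist activity at C-X-C chemokine receptor type 3 (Homo sapiens), read by FLIPR and calcium flux (on this read-out lower numbers stand for stronger inhibition and higher numbers for weaker inhibition), compound 1 gives 1580 nM. Compound 2 `CC1(C)[C@@H]2CC[C@@]1(CS(=O)(=O)N1CCN(c3ccc(C(F)(F)F)c(Cl)n3)CC1)C(=O)C2` gives 251 nM in this assay, a gap that lies beyond the scatter, so the 5-bromopyridin-2-yl compound 1 stands highest of the two numbers. The next step takes compound 3 `CC1(C)[C@@H]2CC[C@@]1(CS(=O)(=O)N1CCN(c3ccc(C(F)(F)F)cc3)CC1)C(=O)C2`, which differs from compound 1 in one place: 4-(trifluoromethyl)phenyl in place of 5-bromopyridin-2-yl on an amine nitrogen in a ring. Among the measured compounds shown here, no measured pair isolates this change. For the measured compounds named here, the trifluoromethyl-bearing ring is shared with compound 2 at 251 nM, while the loss of the ring nitrogen has no precedent here; the expected step from compound 1 to compound 3 is a 2.5-fold lower number from compound 1 to compound 3 (0.40 log units; beyond the scatter), toward stronger inhibition but with wide uncertainty. Compound 3 is therefore estimated at 630 nM in this assay, with a range from 160 nM to 2500 nM.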

Compound 3, half-maximal inhibitory concentration: > 31600 nM
Compound 3: only a limit was reported; the forecaster's own chance of this, stated with the estimate: 5%; at least 50-fold (1.70 log units) between middle value and limit.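

In this assay, 4-(trifluoromethyl)phenyl in place of 5-bromopyridin-2-yl on the amine nitrogen in the ring gives an at least 20-fold higher number from compound 1 to compound 3 (1.30 log units; beyond the scatter), a large loss of inhibition from a single change. The value for compound 3 is a limit of the assay and not a number: the limit of > 31600 nM in this assay, at which 1 of the 3 values shown sits. Compound 1 and compound 2 both carry a pyridine ring at this position and both give a readable number, so only now is it seen that one change of this aromatic group can take the series out of the measurable range.

The change swaps the ring nitrogen and the bromine at once, which leaves open which of the two carries the step. A phenyl ring bearing bromine, or a pyridine ring bearing trifluoromethyl, on the same nitrogen would separate them.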